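Swapping nitro for methyl on a biaryl imidazoline

This account rests on a few compounds, and the source may have more. Where it says the series, first, only, none or still open, it means among the compounds named here.

Compound 1 `CC(Oc1ccccc1-c1ccccc1[N+](=O)[O-])C1=NCCN1`: in a functional assay on CHO cells for agonist activity at Alpha-2B adrenergic receptor (Homo sapiens) (on this read-out lower numbers stand for smaller maximal responses and higher numbers for larger maximal responses), compound 1 reaches only the limit < 0.3.
Compound 2 `CC(Oc1ccccc1-c1ccccc1)C1=NCCO1`: in this assay compound 2 likewise sits at the limit < 0.3.

Both measured results are limits of the assay rather than numbers, so compound 1 stands at the limit of < 0.3 in this assay, at which 2 of the 2 values shown sit, with nothing to set it apart. Compound 3 `Cc1ccccc1-c1ccccc1OC(C)C1=NCCN1` differs from compound 1 by methyl in place of nitro on an aromatic carbon. Within the data shown here, no measured step connects the two, so the change is expected to move this assay little, if at all, beyond the usual scatter. The step that the limit leaves unreadable from compound 1 to compound 3 is expected to be small. Compound 3 is estimated to give 0.25, within 0.1 to 0.5.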

Compound 3, intrinsic activity: the largest response reached, as a fraction of the reference agonist's: < 0.3
Compound 3 ended at the assay's limit; the forecaster's own chance of this, stated with the estimate: 60%; the middle value lies beyond the limit too.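

No step from compound 1 to compound 3 can be read, because both compounds rest at a limit rather than a number: the limit of < 0.3 in this assay, at which 3 of the 3 values shown sit.

The compounds shown leave open how large a response each gives in this assay, and whether swapping nitro for methyl changes it at all.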